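The source may hold more compounds than are shown below. What is called first, only, known or untested is meant among the compounds shown, and "the series" means these compounds.

Compound 1 `COc1nc(C)cc(SC)c1NC(=O)N(Cc1ccc(Oc2ccc(F)cc2)cc1)C1CCCCCC1`: < 0.032 mg/kg
Compound 2 `Cc1cc(S(C)(=O)=O)c(NC(=O)N(Cc2ccc(Oc3ccc(F)cc3)cc2)C2CCCCCC2)c(S(C)(=O)=O)n1`: 0.068 mg/kg

In a functional assay on the whole organism with Rattus norvegicus as the target (a higher number here means that more compound is needed for the effect, a lower number that less compound is needed), compound 1 stands at < 0.032 mg/kg, which is a limit of the assay and not a number. Compound 2 gives a true reading of 0.068 mg/kg. Compound 3 `Cc1cc(C)c(NC(=O)N(Cc2ccc(Oc3ccc(F)cc3)cc2)C2CCCCCC2)c(C)n1` keeps the rest of compound 1 and changes a single group: a group of 9 heavy atoms (8 carbon, 1 nitrogen; one six-membered aromatic ring with 1 hetero atom) in place of a group of 11 heavy atoms (8 carbon, 1 nitrogen, 1 oxygen, 1 sulfur; one six-membered aromatic ring with 1 hetero atom), on an amide-type nitrogen. Among the compounds with values here, no measured pair shows what this swap does, so the following figures are expectations only. A modest shift towards more compound being needed is expected, and the estimated step is an at least 3.1-fold higher number from compound 1 to compound 3 (0.49 log units; beyond the scatter). Compound 3 is estimated at 0.1 mg/kg, with an expected range of 0.03 mg/kg to 0.35 mg/kg.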

Compound 3, dose for half-maximal effect: 0.044 mg/kg
Compound 3: middle estimate off by 2.3-fold (0.36 log units), on the high side; measured number inside the range.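

Putting 2,4,6-trimethylpyridin-3-yl on the amide-type nitrogen in this assay gives an at least 1.3-fold higher number from compound 1 to compound 3 (0.13 log units; that floor lies within the scatter). Without the oxygen and sulfur of the group it replaces, compound 3 still gives a true reading of 0.044 mg/kg. The full size of the step stays unknown because the value of compound 1 is a limit of the assay and not a number: the limit of < 0.032 mg/kg in this assay, at which 1 of the 3 values shown sits.

Several atoms change at once, so the effect of each one alone remains open. Also open, as far as these compounds go, is how a group carrying an amine or a carboxylic acid would behave at this place.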